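Swapping the aryl ether group in a peptide-like inhibitor

The source may hold more compounds than are shown below. What is called first, only, known or untested is meant among the compounds shown, and "the series" means these compounds.

Among the compounds with values here, compound 1 `CC(C)[C@H](NC(=O)COc1cccc2ccccc12)C(=O)N[C@@H](CC(=O)O)C(=O)COc1ccc2ccccc2c1` has the highest of the two numbers so far: in a functional assay with Homo sapiens as the target (a higher number here means a weaker inhibitor, a lower number a stronger inhibitor), compound 1 gives 15900 nM. Compound 2 `CC(C)[C@H](NC(=O)COc1cccc2ccccc12)C(=O)N[C@@H](CC(=O)O)C(=O)COc1ccc(F)cc1` differs at the aryl ether end, and in this assay compound 2 gives 14300 nM; the change a 1.1-fold lower number from compound 1 to compound 2 (0.05 log units; within the scatter) stays within the scatter. Compound 3 `CC(C)[C@H](NC(=O)COc1cccc2ccccc12)C(=O)N[C@@H](CC(=O)O)C(=O)COc1cccc(C(F)(F)F)c1F` carries a different change at the same place: 2-fluoro-3-(trifluoromethyl)phenyl in place of naphthalen-2-yl on an oxygen on a saturated carbon. Within the data shown here, the one comparable step, a single aromatic ring replacing the bicyclic one, moved nothing, so no step beyond the scatter is expected in this assay. For compound 3 the expected value is 14000 nM, ranging from 6000 nM to 35000 nM. The expected step is a 1.1-fold lower number from compound 1 to compound 3 (0.06 log units; within the scatter).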

Compound 3, half-maximal inhibitory concentration: 18200 nM
For compound 3 the middle estimate is 1.3-fold (0.11 log units) below the measured one, within the range that was stated.
By their numbers in this assay, from the lowest: compounds 2, 1 and 3 (each within the scatter of the next).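

In this assay, replacing naphthalen-2-yl with 2-fluoro-3-(trifluoromethyl)phenyl gives a 1.1-fold higher number from compound 1 to compound 3 (0.06 log units; within the scatter) and replacing 4-fluorophenyl with it gives a 1.3-fold higher number from compound 2 to compound 3 (0.10 log units; within the scatter) as the result. The three groups on this oxygen, one with two aromatic rings and two with one ring and different fluorine patterns, therefore cannot be told apart in this assay. No evidence on hand accounts for this flat result. On these data alone, what an amine on the ring, or a plain alkyl chain in place of the ring, would do at this position remains open.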